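Swapping the aryl group on the amidoxime nitrogen

The source may report more compounds than this note shows. Statements on the series, on what has been measured and on what is new or still open speak of the compounds shown alone.

Of the compounds shown here, three have been measured in an assay on HeLa cells for inhibition of Indoleamine 2,3-dioxygenase 1 (Homo sapiens); on this read-out lower numbers stand for stronger inhibition and higher numbers for weaker inhibition. Compound 1, `Cc1ccc(NC(=O)Nc2cc(/C(=N/O)Nc3ccc(F)c(Br)c3)ccc2N(CC(C)C)CC(C)C)cc1`, gives 760 nM. Among the compounds with values here, compound 2, `CCCNC(=O)Nc1cc(/C(=N/O)Nc2ccc(F)c(Br)c2)ccc1N(CC(C)C)CC(C)C`, gives 2610 nM; the only one-point change among the measured pair is a 3.4-fold higher number from compound 1 to compound 2 (0.54 log units; beyond the scatter), a change on the urea side of the shared core. Compound 3, `Cc1ccc(N/C(=N\O)c2ccc(N(CC(C)C)CC(C)C)c(NC(=O)Nc3cncnc3)c2)cc1`, gives 440 nM, a number that sits within the scatter of compound 1 and is clearly lower than compound 2.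

Compound 4, `CC(C)CN(CC(C)C)c1ccc(/C(=N/O)Nc2ccc(F)c(Br)c2)cc1NC(=O)Nc1cncnc1`, is not yet measured. It differs from compound 3 by 3-bromo-4-fluorophenyl in place of 4-methylphenyl on an amine nitrogen. Within the data shown here, compounds 1 and 2 already carry 3-bromo-4-fluorophenyl at that same position, yet each also differs from compound 3 on the urea side, so no measured step isolates this swap. Among the measured compounds shown here, the one measured step concerns a different position and cannot guide it. With nothing pointing in either direction, the expectation for compound 4 is a step of a 1.0-fold higher number from compound 3 to compound 4 (0.01 log units; within the scatter), no larger than the scatter. Compound 4 is therefore estimated at 450 nM, within a range from 150 nM to 1400 nM.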

Compound 4, half-maximal inhibitory concentration: 860 nM
For compound 4 the middle estimate is 1.9-fold (0.28 log units) below the measured one; measured number inside the range.
By their numbers in this assay, from the lowest: compounds 3, 1 and 4 (each within the scatter of the next); then compound 2.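

In this assay, the swap on the amine nitrogen can now be read on its own: with pyrimidin-5-yl on the urea side, 3-bromo-4-fluorophenyl in place of 4-methylphenyl gives a 2.0-fold higher number from compound 3 to compound 4 (0.29 log units; within the scatter) and so leaves the number within the usual scatter. With 3-bromo-4-fluorophenyl held fixed, the urea side shows a propyl chain set apart from both aromatic rings: pyrimidin-5-yl in place of propyl gives a 3.0-fold lower number from compound 2 to compound 4 (0.48 log units; beyond the scatter) while pyrimidin-5-yl in place of 4-methylphenyl gives a 1.1-fold higher number from compound 1 to compound 4 (0.05 log units; within the scatter) and so does not separate the two rings. No measurement offered here explains these steps.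

Still open, from the compounds shown here alone, is what 3-bromophenyl or 4-fluorophenyl alone would give on the amine nitrogen. Also open, going by these compounds, is how a longer alkyl chain or a saturated ring such as morpholine would compare on the urea side.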